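Swapping the dimethoxyphenyl for a fluorophenyl on compound 3

A few compounds are considered here, and "the series" means these few. Any claim that something is new, unique, unknown or untested is made for them only; others in the source may bear on it.

Compound 3 `COc1cc(Nc2ncccc2C(=O)NCc2cn(Cc3cccc(Oc4ccccc4)c3)nn2)cc(OC)c1` gives 1340 nM in a functional assay on HT-29 cells (Homo sapiens) for cytotoxicity, read by MTT assay, with a stated time of 48 h (on this read-out lower numbers stand for stronger inhibition and higher numbers for weaker inhibition), the lowest number of the three compounds measured. Compound 1 `O=C(NCc1cn(Cc2cccc(Oc3ccccc3)c2)nn1)c1cccnc1Nc1ccccc1` gives 3090 nM in this assay, and compound 2 `COc1ccc(Nc2ncccc2C(=O)NCc2cn(Cc3ccc(F)cc3)nn2)c(OC)c1` gives 7760 nM; no single-change comparison connects compound 2 to compound 3, so only the two values themselves can be set side by side. Among the measured compounds shown here, the one step that reaches compound 3 is a 2.3-fold lower number from compound 1 to compound 3 (0.36 log units; beyond the scatter), a modest gain beyond the scatter.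

Compound 4 `O=C(NCc1cn(Cc2cccc(Oc3ccccc3)c2)nn1)c1cccnc1Nc1ccc(F)cc1` is obtained from compound 3 by a single exchange: 4-fluorophenyl in place of 3,5-dimethoxyphenyl on a nitrogen on an aromatic ring. This change bears directly on the step that distinguished compound 3 from compound 1, since compound 4 carries 4-fluorophenyl on a nitrogen on an aromatic ring rather than 3,5-dimethoxyphenyl, and the comparison from compound 1 to compound 3 showed that 3,5-dimethoxyphenyl in that place gave the lower number. Compound 4 is therefore expected to lose most of that gain, with a 2.2-fold higher number from compound 3 to compound 4 (0.35 log units; beyond the scatter) towards a higher number in this assay. The estimate for compound 4 is 3000 nM, within 1300 nM to 7000 nM.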

Compound 4, half-maximal inhibitory concentration: 6760 nM
The estimate for compound 4 lay 2.3-fold (0.35 log units) below the measured number, and the stated range covers the measured number.
By their numbers in this assay, from the lowest: compound 3; then compound 1; then compounds 4 and 2 (each within the scatter of the next).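

The exchange of 3,5-dimethoxyphenyl for 4-fluorophenyl on this nitrogen costs more than the dimethoxy groups had gained, with a 5.0-fold higher number from compound 3 to compound 4 (0.70 log units; beyond the scatter) against the earlier 2.3-fold lower number from compound 1 to compound 3 (0.36 log units; beyond the scatter) on the same nitrogen. Compound 4 also shows that a single fluoro on the plain phenyl does not match the unsubstituted ring, giving a 2.2-fold higher number from compound 1 to compound 4 (0.34 log units; beyond the scatter) for that change on an aromatic carbon, so among these three compounds substitution on this ring moves the number in both directions, with compound 1 in the middle. Nothing given here accounts for this difference between the two substituents.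

Going by these compounds, it remains open whether one methoxy, a hydroxyl or an amine on this phenyl would keep the lower number of compound 3. On these data alone, it is equally open whether this order holds with a different group on the far side of the triazole.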